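Methoxy placement in two aryl acetamide cores

The source may report more compounds than this note shows. Statements on the series, on what has been measured and on what is new or still open speak of the compounds shown alone.

Three compounds have been measured in an assay on NIH3T3 cells for displacement of a labelled ligand from melatonin receptor type 1A (Homo sapiens), with a stated time of 90 min; a higher number here means a weaker inhibitor, a lower number a stronger inhibitor:

Compound 1, `CC(=O)NCCOc1ccccc1`: 11500 nM
Compound 2, `COc1cccc(OCCNC(C)=O)c1`: 40.7 nM
Compound 3, `CC(=O)NCCSc1ccccc1`: 3800 nM

Compound 1 and compound 2 share a core and differ only by methoxy in place of hydrogen on an aromatic carbon This single change produced a 280-fold lower number from compound 1 to compound 2 (2.45 log units; beyond the scatter) Compound 3 carries a different core; the difference between the two cores is not broken down here, and its value in this assay sits closer to compound 1 than to compound 2.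

Compound 4, `COc1ccc(SCCNC(C)=O)cc1` has not been measured. It stands to compound 3 as compound 2 stands to compound 1: methoxy in place of hydrogen on an aromatic carbon The place is not the same, however. In compound 2 the methoxy sits meta to a group of 7 heavy atoms, in compound 4 para to a group of 7 heavy atoms, so this is the same kind of change, not the same change.

In this assay, going by the values given here, the step from compound 3 is expected to be a 3.8-fold lower number from compound 3 to compound 4 (0.58 log units; beyond the scatter), smaller than the step seen from compound 1 to compound 2, since the place of the methoxy differs and only one example of the change has been measured. Compound 4 is therefore estimated at 1000 nM, between 150 nM and 6000 nM.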

Compound 4, inhibition constant: 2820 nM
Compound 4: the middle estimate sits 2.8-fold (0.45 log units) below what was measured; low and high end bracket the measured number.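

In this assay, methoxy in place of hydrogen on an aromatic carbon did not behave alike on the two cores, and the gap between the two steps lies beyond the scatter: the same change on two cores in this assay, a 280-fold lower number (2.45 log units; beyond the scatter) from compound 1 to compound 2 and a 1.3-fold lower number (0.13 log units; within the scatter) from compound 3 to compound 4, 210-fold (2.32 log units) apart, beyond the scatter of two such steps. On the core of compound 3, with the methoxy para to a group of 7 heavy atoms, the change gave a 1.3-fold lower number from compound 3 to compound 4 (0.13 log units; within the scatter), so this pair shows no measurable effect of the change, whereas the pair on the other core shows a large one. The two pairs differ both in the core and in the place of the methoxy, so these data do not show which of the two accounts for the gap, and two examples set no rule for the series.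

The compounds shown leave open how methoxy would act on the core of compound 3 in the place it holds in compound 2, and on the core of compound 1 in the place it holds in compound 4. They also leave open what a chlorine or a hydroxyl group on the aromatic ring, or a longer chain on the amide carbonyl, would do on either core.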